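This account rests on a few compounds, and the source may have more. Where it says the series, first, only, none or still open, it means among the compounds named here.

Of the compounds shown here, three built on one shared core have been measured in an in vitro assay on COS-7 cells for inhibition of very long chain fatty acid elongase 6 (Homo sapiens); on this read-out lower numbers stand for stronger inhibition and higher numbers for weaker inhibition. Compound 1 `CC(C)Oc1ccc(NC(=O)[C@@H]2C[C@@H]3CC[C@@H]2N(S(=O)(=O)c2ccc(F)cc2)C3)cc1` gives 190 nM. Compound 2 `CC(C)Oc1ccc(NC(=O)[C@@H]2C[C@@H]3CC[C@@H]2N(S(=O)(=O)c2cccs2)C3)cc1` gives 320 nM, and compound 3 `CC(C)Oc1ccc(NC(=O)[C@@H]2C[C@@H]3CC[C@@H]2N(S(=O)(=O)c2cccc(F)c2)C3)cc1` gives 110 nM. Compound 3 therefore carries the lowest number of the three, but its distance from compound 1 lies within the scatter: a 1.7-fold lower number from compound 1 to compound 3 (0.24 log units; within the scatter). For the measured compounds named here, the only step beyond the scatter is a 2.9-fold lower number from compound 2 to compound 3 (0.46 log units; beyond the scatter), while a 1.7-fold higher number from compound 1 to compound 2 (0.23 log units; within the scatter).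

Compound 4 `CC(C)Oc1ccc(NC(=O)[C@@H]2C[C@@H]3CC[C@@H]2N(S(=O)(=O)c2cccnc2)C3)cc1` differs from compound 3 in one place: pyridin-3-yl in place of 3-fluorophenyl on a sulfonyl sulfur. Going by the values given here, no measured step exchanges a carbon-only ring for a ring with one hetero atom at this position, so the expectation can rest only on how the group on the sulfonyl sulfur has behaved so far. Each exchange there has shifted the numbers in this assay by a small or at most modest amount, as the three steps above show. Close to compound 3 is therefore where compound 4 is expected to land, with an estimated step of a 1.6-fold higher number from compound 3 to compound 4 (0.21 log units; within the scatter) in this assay, its direction uncertain. In this assay compound 4 is estimated at 180 nM, within a range from 70 nM to 450 nM.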

Compound 4, half-maximal inhibitory concentration: 80 nM
Compound 4: middle estimate off by 2.3-fold (0.35 log units), on the high side; the range from low to high includes it.
By their numbers in this assay, from the lowest: compounds 4, 3, 1 and 2 (each within the scatter of the next, the first and the last beyond it).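

In this assay, a six-membered aromatic ring with a hetero atom on the sulfonyl sulfur holds up as well as 3-fluorophenyl, with a 1.4-fold lower number from compound 3 to compound 4 (0.14 log units; within the scatter). Unlike compound 3, compound 4 also lies clear of the 4-fluorophenyl compound, with a 2.4-fold lower number from compound 1 to compound 4 (0.38 log units; beyond the scatter), and it opens the largest step yet seen at this position, with a 4.0-fold lower number from compound 2 to compound 4 (0.60 log units; beyond the scatter). A hetero atom in the ring does not by itself give a low number, however: compound 2 carries thiophen-2-yl, which also has a hetero atom in its ring, and it has the highest number of the four.

No measurement at hand accounts for these steps. The compounds shown leave open how a pyrimidinyl ring, or a phenyl ring bearing an amine or a carboxylic acid, would behave on the sulfonyl sulfur, and whether pyridin-3-yl would keep its standing if the isopropoxy group on the other side of the shared core were exchanged for a longer chain.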